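From cyclopentyl to cyclohexyl on an amide-type nitrogen

The source may hold more compounds than are shown below. What is called first, only, known or untested is meant among the compounds shown, and "the series" means these compounds.

Values in a functional assay on LoVo cells (Homo sapiens) for antiproliferative activity, read by MTT assay, with a stated time of 72 h; on this read-out higher numbers stand for weaker inhibition and lower numbers for stronger inhibition:
- Compound 1 `Cc1noc(C)c1-c1nn(Cc2ccc(C(=O)NC3CC3)cc2)c(=O)c2ccccc12`: > 100000 nM
- Compound 2 `Cn1cc(Nc2nn(Cc3ccc(C(=O)NC4CCCCC4)cc3)c(=O)c3ccccc23)cn1`: 5300 nM
- Compound 3 `Cc1noc(C)c1-c1nn(Cc2ccc(C(=O)NC3CCCC3)cc2)c(=O)c2ccccc12`: > 100000 nM

Only compound 2 has a number, since the other two entries are limits of the assay. Compound 3 gives > 100000 nM, which is a limit and not a number. Compound 1 and compound 3 both sit at the limit of > 100000 nM in this assay, at which 2 of the 3 values shown sit.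

Compound 4 `Cc1noc(C)c1-c1nn(Cc2ccc(C(=O)NC3CCCCC3)cc2)c(=O)c2ccccc12` keeps the core of compound 3 and has cyclohexyl in place of cyclopentyl on an amide-type nitrogen. Among the measured compounds shown here, the one measured step of this kind is a step that the two limits leave unreadable from compound 1 to compound 3, so it supplies no size to carry over. Cyclohexyl also sits on compound 2, but that compound differs from the others elsewhere on the core, and its number cannot simply be transferred. With no readable step to suggest a change, no shift beyond the scatter is expected in this assay, in either direction. The expected step is an at least 1.1-fold lower number from compound 3 to compound 4 (0.04 log units; that floor lies within the scatter). Compound 4 is estimated at 90000 nM, with an expected range from 25000 nM to 150000 nM. A report of only a limit is expected to be the likeliest outcome.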

Compound 4, half-maximal inhibitory concentration: 82200 nM
For compound 4 the middle estimate is 1.1-fold (0.04 log units) above the measured one; low and high end bracket the measured number.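

On the amide-type nitrogen, cyclohexyl gives the 3,5-dimethyl-1,2-oxazol-4-yl compounds a readable number in this assay, but the steps are an at least 1.2-fold lower number from compound 3 to compound 4 (0.08 log units; that floor lies within the scatter) and an at least 1.2-fold lower number from compound 1 to compound 4 (0.08 log units; that floor lies within the scatter), so no change beyond the scatter is established for this swap of carbon rings. The two compounds with smaller rings on that nitrogen remain limits and not numbers: the limit of > 100000 nM in this assay, at which 2 of the 4 values shown sit.

Among the compounds shown here, with cyclohexyl held in place, the group on the aromatic carbon now gives a readable comparison, with a 16-fold higher number from compound 2 to compound 4 (1.19 log units; beyond the scatter), and this is the only step among the new ones that is printed as beyond the scatter.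

Among the compounds shown, the (1-methyl-1H-pyrazol-4-yl)amino group appears only with cyclohexyl on the amide-type nitrogen, so it remains open whether cyclopropyl or cyclopentyl would give a readable number alongside it. Also open, as far as these compounds go, is how an open-chain group such as tert-butyl, or a ring carrying an amine such as piperidin-4-yl, would read on that nitrogen in this assay.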